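A few compounds are considered here, and "the series" means these few. Any claim that something is new, unique, unknown or untested is made for them only; others in the source may bear on it.

Compound 1 `N#Cc1cnc(NCc2cnccc2C(F)(F)F)cc1N[C@H]1C[C@@H](O)C1` gives 500 nM in an assay on isolated protein for inhibition of protein kinase C theta type (Homo sapiens), read by TR-FRET, with a stated time of 2 h; on this read-out lower numbers stand for stronger inhibition and higher numbers for weaker inhibition; compound 2 `CO[C@H]1CC[C@H](CNc2cc(NCc3cnccc3C(F)(F)F)ncc2C#N)CC1` gives 330 nM.

For the measured compounds named here, of the two numbers in this assay, compound 2 is the one nearest to compound 1, and the step of a 1.5-fold lower number from compound 1 to compound 2 (0.18 log units; within the scatter) is within the scatter, so the two measured compounds cannot be told apart on potency. Compound 3 `N#Cc1cnc(NCc2cnccc2C(F)(F)F)cc1NC1CCOCC1` differs from compound 2 in one place: oxan-4-yl in place of (4-methoxycyclohexyl)methyl on a nitrogen on an aromatic ring. Going by the values given here, the only measured step that bears on this position is the one from compound 1 to compound 2, which swapped one substituent on the same nitrogen for another and moved the number only within the scatter. Among the compounds with values here, with that as the sole guide, compound 3 is expected to stay close to compound 2, and the expected step of a 1.4-fold higher number from compound 2 to compound 3 (0.13 log units; within the scatter) is not one beyond the scatter. Compound 3 is therefore estimated at 450 nM, with a range from 200 nM to 1100 nM.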

Compound 3, half-maximal inhibitory concentration: 900 nM
The estimate for compound 3 lay 2.0-fold (0.30 log units) below the measured number; the range from low to high includes it.
By their numbers in this assay, from the lowest: compounds 2, 1 and 3 (each within the scatter of the next, the first and the last beyond it).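

In this assay, for the compounds shown here, the substituent on this nitrogen now shows a measurable effect: oxan-4-yl in place of (4-methoxycyclohexyl)methyl gives a 2.7-fold higher number from compound 2 to compound 3 (0.44 log units; beyond the scatter) and is the first step here beyond the scatter. Oxan-4-yl in place of 3-hydroxycyclobutyl gives only a 1.8-fold higher number from compound 1 to compound 3 (0.26 log units; within the scatter) and so stays within the scatter, which means that compound 3 separates from compound 2 but not from compound 1. Nothing available explains the larger step.

The compounds shown leave open which part of the change from compound 2 to compound 3 matters, since the ring, the methoxy group and the methyl link all change together. They also leave open how this nitrogen would tolerate a substituent carrying an amine or a carboxylic acid, or a plain cyclohexyl ring with no oxygen.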